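This account rests on a few compounds, and the source may have more. Where it says the series, first, only, none or still open, it means among the compounds named here.

Of the compounds shown here, two built on a shared core have been tested so far in a functional assay on the whole organism (strain Swiss Albino) for inhibition, with Mus musculus as the target, read by paw edema, with a stated time of 360 min, at a dose of 100 mg/kg by the oral route; a higher number here means more inhibition at the dose given (going by the name of the read-out), a lower number less inhibition. Compound 1 `CNC(=S)N1N=C(c2ccc(C)cc2)CC1c1ccc[nH]1` gives 16.3% in this assay. Compound 2 `CCNC(=S)N1N=C(c2ccc(C)cc2)CC1c1ccc[nH]1` gives 16.3% in this assay. Among the measured compounds shown here, the one measured step between them, no change at the digits printed from compound 1 to compound 2 (within the scatter), is methyl in place of hydrogen on a saturated chain carbon bound to an amide-type nitrogen, and it left the read-out unmoved within the scatter. On these numbers compound 2 stands level with compound 1, and nothing separates the two beyond the usual spread of repeats.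

Compound 3 `CCCNC(=S)N1N=C(c2ccc(C)cc2)CC1c1ccc[nH]1` has not yet been measured in this assay. It differs from compound 2 by methyl in place of hydrogen on a saturated chain carbon, two bonds along the chain from an amide-type nitrogen. For the measured compounds named here, this is the same kind of lengthening of the chain on the nitrogen as in the one measured step, cut one bond further out. Going by the values given here, the only step that bears on it, no change at the digits printed from compound 1 to compound 2 (within the scatter), showed no change within the scatter, so a further lengthening of the same kind is expected to do the same, and the estimate therefore implies no change at the digits printed from compound 2 to compound 3 (within the scatter), no change beyond the scatter. Compound 3 is accordingly expected to give about 16.3% in this assay, with a likely range from 6% to 27%.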

Compound 3, a percentage reported as inhibition, in the whole organism at one dose (the size of the read-out at that dose, not a potency): 22.7%
For compound 3 the middle estimate is 6.4 percentage points below the measured one; measured number inside the range.
By their numbers in this assay, from the lowest: compounds 1, 2 and 3 (each within the scatter of the next).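

Going from ethyl to propyl on the nitrogen gives a number 6.4 percentage points higher from compound 2 to compound 3 (within the scatter) in this assay, so this added methyl, two bonds along the chain from the amide-type nitrogen, stays within the usual spread of repeats, as the methyl added in the earlier step did. Taken as a single change, ethyl in place of hydrogen on the saturated chain carbon bound to the amide-type nitrogen gives a number 6.4 percentage points higher from compound 1 to compound 3 (within the scatter), so even the full span from the methyl chain of compound 1 to the propyl chain of compound 3 does not separate the compounds in this assay. No independent measurement accompanies these numbers to explain them.

The compounds shown leave open whether a longer chain such as butyl or hexyl, a branched chain such as isopropyl, or a ring such as phenyl or cyclohexyl on this nitrogen would move the read-out beyond the scatter. An amine or a carboxylic acid at the end of the chain also remains an open case, as does the way these compounds compare at other doses, since a reading at one dose shows the size of the effect there and not a potency.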